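Group exchange on the chain: notes on cytotoxicity

A few compounds are considered here, and "the series" means these few. Any claim that something is new, unique, unknown or untested is made for them only; others in the source may bear on it.

Measured so far in a functional assay on A549 cells (Homo sapiens) for cytotoxicity, read by MTT assay, with a stated time of 72 h; on this read-out lower numbers stand for stronger inhibition and higher numbers for weaker inhibition:
- compound 1 `CNC(=O)c1cc(Oc2ccc(C(=O)/C=C/c3cccc(Br)c3)cc2)ccn1`: 9940 nM
- compound 2 `CNC(=O)c1cc(Oc2ccc(C(=O)/C=C/c3ccc(F)cc3Cl)cc2)ccn1`: 21100 nM

Compound 2 stands highest of the two numbers, at 21100 nM, and is the weaker of the pair. Compound 3 `CNC(=O)c1cc(Oc2ccc(C(=O)/C=C/c3ccc(C#N)cc3)cc2)ccn1` is next, with 4-cyanophenyl in place of 2-chloro-4-fluorophenyl on a double-bonded chain carbon bound to a double-bonded chain carbon.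

Among the compounds with values here, one measured step bears on this change, at the same place: a 2.1-fold higher number from compound 1 to compound 2 (0.33 log units; beyond the scatter). It is modest, so a group exchange there has so far moved this assay only a little. Neither measured compound carries the nitrile, and two compounds establish no pattern. Within the data shown here, compound 2 is the only one with the leaving group, so the expectation is a small shift toward a lower number, not much beyond the scatter if it exceeds it at all. The expected step is a 1.8-fold lower number from compound 2 to compound 3 (0.25 log units; within the scatter). The estimate for compound 3 is 12000 nM, with an expected range from 5000 nM to 28000 nM.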

Compound 3, half-maximal inhibitory concentration: 26400 nM
The estimate for compound 3 lay 2.2-fold (0.34 log units) below the measured number, within the range that was stated.
By their numbers in this assay, from the lowest: compound 1; then compounds 2 and 3 (each within the scatter of the next).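

In this assay, within the data shown here, 4-cyanophenyl in place of 2-chloro-4-fluorophenyl gives a 1.3-fold higher number from compound 2 to compound 3 (0.10 log units; within the scatter) and so does not separate these two groups at this place on a double-bonded chain carbon, even though the entering group brings a nitrile with a hydrogen-bond acceptor and the leaving group brings chlorine and fluorine. 4-cyanophenyl in place of 3-bromophenyl gives a 2.7-fold higher number from compound 1 to compound 3 (0.42 log units; beyond the scatter), a modest step that, with the earlier step from compound 1 to compound 2, leaves compound 1 with the lowest number of the three and makes 3-bromophenyl the only group here that stands apart. Nothing at hand accounts for either step.

From the compounds shown here alone, it remains open whether the lower number of compound 1 is tied to bromine as such or to 3-bromophenyl in particular, which 4-bromophenyl or 3-chlorophenyl at the same place would test. Also open, going by these compounds, is how a phenyl ring bearing an amine or a carboxylic acid would read in this assay at this place, since all three groups compared so far are substituted phenyl rings carrying halogen or nitrile.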